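The source may hold more compounds than are shown below. What is called first, only, known or untested is meant among the compounds shown, and "the series" means these compounds.

Measured so far:
- compound 1 `Cc1nnc(-c2ccc(N3CCC(Oc4ccccc4C(F)(F)F)CC3)nn2)s1`: 2.3 nM
- compound 2 `CC(=O)c1ccccc1OC1CCN(c2ccc(-n3ccnc3)nn2)CC1`: 34 nM

In an assay on microsomes from liver for inhibition of acyl-CoA desaturase 1 (Rattus norvegicus) (on this read-out higher numbers stand for weaker inhibition and lower numbers for stronger inhibition), compound 1 gives 2.3 nM, the lower of the two numbers at hand. Within the data shown here, compound 2 gives 34 nM, a gap that lies beyond the usual scatter, so compound 1 is the stronger inhibitor of the pair; with only two compounds, no pattern can be drawn from this.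

Compound 3 `CC(C)(C)c1nnc(-c2ccc(N3CCC(Oc4ccccc4C(F)(F)F)CC3)nn2)o1` has not yet been measured. It differs from compound 1 in one place: 5-(tert-butyl)-1,3,4-oxadiazol-2-yl in place of 5-methyl-1,3,4-thiadiazol-2-yl on an aromatic carbon. Among the measured compounds shown here, no step between measured compounds resembles this change, so its size cannot be read from the data. The shared core and the rest of compound 1 are kept. In this assay a small step from compound 1 to compound 3 is expected, a 1.7-fold higher number from compound 1 to compound 3 (0.24 log units; within the scatter), within or only just beyond the scatter. Compound 3 is estimated at 4 nM, within 1 nM to 15 nM.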

Compound 3, half-maximal inhibitory concentration: 980 nM
Compound 3: middle estimate off by 250-fold (2.39 log units), on the low side; measured number outside the range, above it.
By their numbers in this assay, from the lowest: compound 1; then compound 2; then compound 3.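

In this assay this position, on an aromatic carbon of a six-membered aromatic ring with 2 nitrogen, is far from indifferent to the group it carries: 5-(tert-butyl)-1,3,4-oxadiazol-2-yl in place of 5-methyl-1,3,4-thiadiazol-2-yl gives a 430-fold higher number from compound 1 to compound 3 (2.63 log units; beyond the scatter). Both groups are five-membered aromatic rings with 3 hetero atoms and have the same donor and acceptor counts, so matching those counts does not preserve inhibition here. No measurement at hand bears on the reason for this loss.

The ring and its alkyl group change together, so 5-methyl-1,3,4-oxadiazol-2-yl and 5-(tert-butyl)-1,3,4-thiadiazol-2-yl at this position would be needed to separate the two contributions. Also open, on these data alone, is how a five-membered ring carrying an ethyl or isopropyl group would read in this assay.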